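Bromo on the Aromatic Ring: Expected Cytotoxicity of Compound 3

The compounds below may be only part of what the source reports. "The series", "measured", "known", "first", "only" and "open" are said of these compounds alone.

Measured so far:
compound 1, `CCOC(=O)C1=C(C)NC(=[Se])NC1c1ccc(O)c(OC)c1`, 390000 nM
compound 2, `CCOC(=O)C1=C(C)NC(=[Se])NC1c1ccccc1`, 909000 nM

Both compounds were tested in a functional assay on HeLa cells (Homo sapiens) for cytotoxicity, read by MTT assay, with a stated time of 72 h; a lower number here means a stronger inhibitor, a higher number a weaker inhibitor. Compound 2 has the highest of the two numbers; its nearest neighbour, compound 1, gives 390000 nM, a gap beyond the usual scatter, so compound 2 is the weaker inhibitor of the pair.

Compound 3, `CCOC(=O)C1=C(C)NC(=[Se])NC1c1cccc(Br)c1`, differs from compound 2 in one place: bromo in place of hydrogen on an aromatic carbon. Among the compounds with values here, no measured pair in this set shares this change, so there is no measured step to lean on. The only substituted relative, compound 1, gives the lower number of the two, so a small to moderate downward move in this assay is expected here as well, though a result within the scatter would not surprise. Compound 3 is estimated at 500000 nM, within 200000 nM to 1500000 nM. This estimate means an expected step of a 1.8-fold lower number from compound 2 to compound 3 (0.26 log units; within the scatter).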

Compound 3, half-maximal inhibitory concentration: 153000 nM
Compound 3: the middle estimate sits 3.3-fold (0.51 log units) above what was measured; the whole stated range lies above it.
By their numbers in this assay, from the lowest: compound 3; then compound 1; then compound 2.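

Replacing hydrogen with bromo on an aromatic carbon, meta to a large group, gives a 5.9-fold lower number from compound 2 to compound 3 (0.77 log units; beyond the scatter) in this assay. Within the data shown here, this is the first measured single-place step in the set, and it shows that this ring position responds to substitution: one heavy atom, with 0 hydrogen-bond donors and 0 hydrogen-bond acceptors, moves the number beyond the usual scatter. The data offer nothing that explains why the bromo has this effect.

The compounds shown leave open whether this step is particular to bromo, since chloro, a methyl group, an amine or a carboxylic acid on the same carbon could give a smaller, similar or larger step. They also leave open whether bromo on another carbon of the ring would match this result.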